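The compounds below may be only part of what the source reports. "The series", "measured", "known", "first", "only" and "open" are said of these compounds alone.

In an ADME assay on microsomes from liver (Mus musculus) for metabolic stability, read by LC-MS, with a stated time of 30 min, tested at 1 uM (a higher number here means that more of the compound is left, a lower number that less of the compound is left), compound 1 `O=C(NCc1ccc(S(=O)(=O)c2ccccc2)cc1)c1nc2cnccc2[nH]1` gives 7.3%, compound 2 `O=C(NCc1ccc(S(=O)(=O)c2ccccc2)cc1)c1cc2ccncc2s1` gives 21% and compound 3 `O=C(NCc1ccc(S(=O)(=O)c2ccccc2)cc1)c1nc2ccncc2s1` gives 26%. The measured steps place compound 3 level with compound 2, a number 5 percentage points higher from compound 2 to compound 3 (within the scatter), and clear of compound 1, a number 18.7 percentage points higher from compound 1 to compound 3 (beyond the scatter). Compound 4 `O=C(NCc1ccc(S(=O)(=O)c2ccccc2)cc1)c1ccc2nccn2c1` differs from compound 3 on a carbonyl carbon whose other neighbours are amide-type nitrogen: a group of 9 heavy atoms (7 carbon, 2 nitrogen; one five-membered aromatic ring with 2 hetero atoms, one six-membered aromatic ring with 1 hetero atom) in place of a group of 9 heavy atoms (6 carbon, 2 nitrogen, 1 sulfur; one five-membered aromatic ring with 2 hetero atoms, one six-membered aromatic ring with 1 hetero atom), on a carbonyl carbon. Its entering group has no sulfur, as in compound 1, so the modest steps of a number 13.7 percentage points higher from compound 1 to compound 2 (beyond the scatter) and a number 18.7 percentage points higher from compound 1 to compound 3 (beyond the scatter) are the closest guide, read in reverse. A modest fall in this assay is therefore expected, with the estimated step of a number 11 percentage points lower from compound 3 to compound 4 (beyond the scatter). The expected value for compound 4 is 15%, within an estimated range of 4% to 35%.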

Compound 4, percent of the compound remaining: 18%
Compound 4: middle estimate off by 3 percentage points, on the low side; the range from low to high includes it.
By their numbers in this assay, from the lowest: compound 1; then compounds 4, 2 and 3 (each within the scatter of the next).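

In this assay, losing the sulfur from the group on the carbonyl carbon does not return the number to the level of compound 1: the result is a number 8 percentage points lower from compound 3 to compound 4 (within the scatter) and a number 3 percentage points lower from compound 2 to compound 4 (within the scatter), yet also a number 10.7 percentage points higher from compound 1 to compound 4 (beyond the scatter). Sulfur is therefore not needed at this position to stand clear of compound 1, since sulfur-free compound 4 does so too. No measured evidence accounts for the gap between the two sulfur-free compounds.

The compounds shown leave open whether any group here could rise clear of compounds 2, 3 and 4. From the compounds shown here alone, a single phenyl ring or a morpholine amide in place of the two-ring groups remains untested in this account.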